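This account rests on a few compounds, and the source may have more. Where it says the series, first, only, none or still open, it means among the compounds named here.

The compounds measured so far:

Compound 1 `Cn1c(CO[C@@H]2COc3nc([N+](=O)[O-])cn3C2)cnc1-c1ccc(F)cc1`: in an ADME assay on Vero cells (Chlorocebus sabaeus) for cytotoxicity, with a stated time of 72 h (a lower number here means a stronger inhibitor, a higher number a weaker inhibitor), compound 1 gives > 128000 nM, which is a limit of the assay.
Compound 2 `Cn1c(CO[C@@H]2COc3nc([N+](=O)[O-])cn3C2)cnc1-c1ccc(OC(F)(F)F)cc1`: in this assay compound 2 gives > 128000 nM, again a limit.
Compound 3 `O=[N+]([O-])c1cn2c(n1)OC[C@@H](OCc1ccn(-c3ccc(F)cc3)n1)C2`: in this assay compound 3 gives > 128000 nM, also a limit.

Compound 1 and compound 2 share the same core and differ in a single place: trifluoromethoxy in place of fluoro on an aromatic carbon. The step that the two limits leave unreadable from compound 1 to compound 2 cannot be read, since both ends are limits rather than numbers. Within the data shown here, every value measured here sits at the limit of > 128000 nM in this assay, at which 3 of the 3 values shown sit, so no compound among the three can be set above or below another in this assay.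

Compound 3 carries a different core. The difference between the core of compound 1 and the core of compound 3 is not broken down here.

Compound 4 `O=[N+]([O-])c1cn2c(n1)OC[C@@H](OCc1ccn(-c3ccc(OC(F)(F)F)cc3)n1)C2` has not yet been measured. It differs from compound 3 in one place: trifluoromethoxy in place of fluoro on an aromatic carbon. Among the measured compounds shown here, this is the same change as the one from compound 1 to compound 2, made at a place described in the same words.

The expected step is essentially nil, a step that the limit leaves unreadable from compound 3 to compound 4, because compound 1 and compound 2 both sit at the limit of > 128000 nM in this assay, at which 3 of the 3 values shown sit, and compound 3 sits there too. Compound 4 is therefore expected to give about 200000 nM in this assay, most probably reported as a limit once more, with an estimated range from 100000 nM to 600000 nM.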

Compound 4, half-maximal inhibitory concentration: > 128000 nM
Compound 4 gave a limit, no number (the forecaster's own chance of this, stated with the estimate: 85%); the middle value does not contradict the limit.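

Compound 3 and compound 4 both end at a limit and not at a number, so the step between them cannot be read and this assay gives no new comparison: the limit of > 128000 nM in this assay, at which 4 of the 4 values shown sit.

The compounds shown leave open where any of them would give a true number in this assay, and whether trifluoromethoxy in place of fluoro shifts that number on either core.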